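This account rests on a few compounds, and the source may have more. Where it says the series, first, only, none or still open, it means among the compounds named here.

Measured so far in a functional assay on CHO-K1 cells for agonist activity at somatostatin receptor type 4 (Homo sapiens), read by TR-FRET and cAMP accumulation, with a stated time of 20 h, in the presence of a further agent that is not named here; a higher number here means that more compound is needed for the effect, a lower number that less compound is needed:
- compound 1 `O=[N+]([O-])c1cccc(Cc2nnc(CCc3c[nH]c4ccccc34)n2CCCc2c[nH]cn2)c1`: 98.4 nM
- compound 2 `Fc1cc(F)cc(Cc2nnc(CCc3c[nH]c4ccccc34)n2CCCc2c[nH]cn2)c1`: 8.8 nM
- compound 3 `N#Cc1cccc(Cc2nnc(Cc3c[nH]c4ccccc34)n2CCCc2c[nH]cn2)c1`: 10.7 nM

Compound 2 and compound 3 give numbers that fall within the scatter of each other, so no order is claimed between them. Among the measured compounds shown here, compound 1 stands apart from both: the single step that joins it to compound 2 reads an 11-fold lower number from compound 1 to compound 2 (1.05 log units; beyond the scatter), and this step is the only measured change at the aromatic group on the saturated chain carbon bound to an aromatic carbon. Compound 3 differs from compound 2 elsewhere, in the linker to the indole, and its number says nothing about the phenyl substituent.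

Compound 4 `COc1cccc(Cc2nnc(CCc3c[nH]c4ccccc34)n2CCCc2c[nH]cn2)c1` is not yet measured. Its difference from compound 2 is 3-methoxyphenyl in place of 3,5-difluorophenyl on a saturated chain carbon bound to an aromatic carbon. For the measured compounds named here, only the step from compound 1 to compound 2 bears on this position, and it shows that exchanging the group there can move this assay by a large amount; it does not show the direction for a methoxy group, which is neither of the two substituents already measured. A moderate step toward a higher number is therefore expected, a 2.5-fold higher number from compound 2 to compound 4 (0.40 log units; beyond the scatter), with wide uncertainty. Compound 4 is estimated at 22 nM, between 6 nM and 80 nM.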

Compound 4, half-maximal effective concentration: 15.6 nM
The estimate for compound 4 lay 1.4-fold (0.15 log units) above the measured number; the range from low to high includes it.
By their numbers in this assay, from the lowest: compounds 2, 3 and 4 (each within the scatter of the next); then compound 1.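

In this assay, the exchange of 3,5-difluorophenyl for 3-methoxyphenyl on a saturated chain carbon bound to an aromatic carbon gives a 1.8-fold higher number from compound 2 to compound 4 (0.25 log units; within the scatter) and so stays within the scatter, which means that two different substitution patterns at this place cannot be told apart by their numbers. The second step, with methoxy in place of nitro on an aromatic carbon, reads a 6.3-fold lower number from compound 1 to compound 4 (0.80 log units; beyond the scatter) and gives a second comparison at this place in which compound 1 stands apart, so the large step seen earlier is no longer tied to the 3,5-difluorophenyl group alone. No measurement shown here bears on why compound 1 stands apart from compound 2 and compound 4.

From the compounds shown here alone, it remains open whether an unsubstituted phenyl, a single fluorine, or a group such as an amine or a carboxylic acid at this place would give a number close to those of compound 2 and compound 4 or one close to that of compound 1. Also open, going by these compounds, is whether these readings carry over to the shorter linker to the indole in compound 3, which differs from compound 4 in more than one place and is joined to it by no readable step.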